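Anilinoquinazoline series: aryl substituent change, compound 3 to 4

This account rests on a few compounds, and the source may have more. Where it says the series, first, only, none or still open, it means among the compounds named here.

Measured so far in a functional assay on SNU-638 cells (Homo sapiens) for cytotoxicity, read by sulforhodamine B assay, with a stated time of 72 h; a higher number here means a weaker inhibitor, a lower number a stronger inhibitor:
compound 1 `CCS(=O)(=O)Nc1cc(-c2ccc3ncnc(Nc4cccc(F)c4)c3c2)cnc1OC` gives 2760 nM
compound 2 `CCS(=O)(=O)Nc1cc(-c2ccc3ncnc(Nc4cccc(C(=O)OC)c4)c3c2)cnc1OC` gives 1120 nM
compound 3 `CCS(=O)(=O)Nc1cc(-c2ccc3ncnc(Nc4ccc(Cl)c(C(=O)OC)c4)c3c2)cnc1OC` gives 2200 nM

Compound 3 sits second highest of the three numbers; its nearest neighbour is compound 1, and the gap between them is within the scatter, as is the gap to compound 2, so no order among these three is claimed.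

Compound 4 `CCS(=O)(=O)Nc1cc(-c2ccc3ncnc(Nc4ccc(C(=O)OC)c(OC)c4)c3c2)cnc1OC` differs from compound 3 by 3-methoxy-4-(methoxycarbonyl)phenyl in place of 4-chloro-3-(methoxycarbonyl)phenyl on a nitrogen on an aromatic ring. Within the data shown here, two measured steps bear on it. The step of a 2.0-fold higher number from compound 2 to compound 3 (0.29 log units; within the scatter) shows that adding chloro to the methoxycarbonyl-bearing ring did not move the number beyond the scatter; the step of a 2.5-fold lower number from compound 1 to compound 2 (0.39 log units; beyond the scatter) shows that methoxycarbonyl in place of fluoro gave a modest lowering. Nothing measured speaks to methoxy on this ring. From the compounds shown here alone, removing chloro may return the number toward that of compound 2, but the added methoxy is untested, so only a step within the scatter is expected for compound 4 in this assay, a 1.5-fold lower number from compound 3 to compound 4 (0.17 log units; within the scatter). Compound 4 is therefore estimated at 1500 nM, with a range from 600 nM to 4000 nM.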

Compound 4, half-maximal inhibitory concentration: 3440 nM
Compound 4: middle estimate off by 2.3-fold (0.36 log units), on the low side, and the stated range covers the measured number.
By their numbers in this assay, from the lowest: compounds 2, 3, 1 and 4 (each within the scatter of the next, the first and the last beyond it).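

In this assay, among these compounds, the one new step beyond the scatter is a 3.1-fold higher number from compound 2 to compound 4 (0.49 log units; beyond the scatter), with 3-methoxy-4-(methoxycarbonyl)phenyl in place of 3-(methoxycarbonyl)phenyl on a nitrogen on an aromatic ring, so a methoxycarbonyl group on this ring does not by itself keep the number at the level of compound 2. The other two steps, a 1.6-fold higher number from compound 3 to compound 4 (0.19 log units; within the scatter) and a 1.2-fold higher number from compound 1 to compound 4 (0.10 log units; within the scatter), lie within the scatter, so compound 4 cannot be ordered against compound 3 or compound 1. No measurement shown accounts for the step beyond the scatter.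

Compound 4 differs from compound 2 by both an added methoxy and a moved methoxycarbonyl, so the contribution of each remains unresolved. From the compounds shown here alone, how a carboxylic acid or an amine on this ring would read in this assay also remains open.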